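The source may hold more compounds than are shown below. What is called first, only, known or untested is meant among the compounds shown, and "the series" means these compounds.

Compound 1 `COc1ccc(OC)c(N2C(=O)CSC2c2cccc(C(=O)NCCCCc3ccccc3)c2)c1` gives 1% in a functional assay on U2OS cells (Homo sapiens) for inhibition, read by CCK-8 assay, with a stated time of 72 h, tested at 1 uM; a higher number here means more inhibition at the concentration tested (going by the name of the read-out), a lower number less inhibition.
Compound 2 `COc1cc(F)ccc1N1C(=O)CSC1c1cccc(C(=O)NCCCCc2ccccc2)c1` gives 34%.
Compound 3 `COc1ccccc1N1C(=O)CSC1c1cc(F)cc(C(=O)O)c1` gives 15%.

Compound 2 stands highest of the three numbers; compound 3 lies below it, and compound 1 lies furthest down, both gaps beyond the scatter. Compound 4 `COc1ccc(N2C(=O)CSC2c2cccc(C(=O)NCCCCc3ccccc3)c2)c(OC)c1` is not yet measured and differs from compound 2 in one place: methoxy in place of fluoro on an aromatic carbon. Among the compounds with values here, the one measured step that bears on this is a number 33 percentage points higher from compound 1 to compound 2 (beyond the scatter), a large gain when a 2,5-dimethoxyphenyl became a 4-fluoro-2-methoxyphenyl. Compound 4 moves back toward a dimethoxyphenyl, though a 2,4-pattern rather than compound 1's, so a drop in this assay is expected, probably partial. Compound 4 is expected to give about 15%, within 0% to 35%. That estimate means a step of a number 19 percentage points lower from compound 2 to compound 4 (beyond the scatter).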

Compound 4, a percentage reported as inhibition, at one concentration (the size of the read-out at that concentration, not a potency): 37%
Beside the measured number, compound 4's estimate is 22 percentage points below it; measured number above the stated range.
By their numbers in this assay, from the lowest: compound 1; then compound 3; then compounds 2 and 4 (each within the scatter of the next).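

At the position para to a large group, methoxy and fluoro cannot be told apart in this assay: a number 3 percentage points higher from compound 2 to compound 4 (within the scatter). A second methoxy on the ring is therefore compatible with inhibition, and where it sits matters: a number 36 percentage points higher from compound 1 to compound 4 (beyond the scatter), a large step for the change from 2,5-dimethoxyphenyl to 2,4-dimethoxyphenyl. No measurement shown here explains this difference.

On these data alone, whether an amine or an ethoxy group at this position would keep the inhibition remains open. So does whether the position needs any group at all, since a plain hydrogen there is not among these compounds.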